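The source may report more compounds than this note shows. Statements on the series, on what has been measured and on what is new or still open speak of the compounds shown alone.

Three compounds have been measured in a functional assay on MCF7 cells (Homo sapiens) for inhibition, read by sulforhodamine B assay, with a stated time of 48 h, tested at 50 uM (a lower number here means less inhibition of growth, a higher number more inhibition of growth at the concentration tested), so far:
compound 1 (`O=C(Nc1cn2cc(I)ccc2n1)C(F)(F)F`) gives 36.7%
compound 2 (`O=C(c1ccc(C(F)(F)F)c(F)c1)c1ccc2nc(NC(=O)C(F)(F)F)cn2c1`) gives 56.5%
compound 3 (`O=C(c1ccc2nc(NC(=O)C(F)(F)F)cn2c1)c1ccc(C(F)(F)F)cc1F`) gives 97.2%

Compound 2 stands in the middle of this short series. Its value of 56.5% is the second highest of the three numbers, above compound 1 and below compound 3, and both gaps lie beyond the scatter. The next compound to be tested is compound 4 (`Cc1ccc(C(=O)c2ccc3nc(NC(=O)C(F)(F)F)cn3c2)cc1F`), which differs from compound 2 in one place (methyl in place of trifluoromethyl on an aromatic carbon). A methyl takes the place of the trifluoromethyl on an aromatic carbon, ortho to a fluoro group and para to a large group.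

Going by the values given here, no measured pair shows this exchange, so the expectation rests on little evidence. The step expected in this assay is small and slightly downward, not beyond the scatter, and it is estimated as follows (a number 6.5 percentage points lower from compound 2 to compound 4 (within the scatter)). The range must stay broad, since compound 1 gives 36.7% and compound 3 gives 97.2% in this small set. For compound 4 the expected value is an estimated 50%, within a range from 28% to 75%.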

Compound 4, percent growth inhibition at one concentration: 57.3%
Beside the measured number, compound 4's estimate is 7.3 percentage points below it; the range from low to high includes it.
By their numbers in this assay, from the lowest: compound 1; then compounds 2 and 4 (each within the scatter of the next); then compound 3.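

In this assay, going by these compounds alone, methyl in place of trifluoromethyl on this aromatic carbon, ortho to a fluoro group and para to a large group, gives the first direct reading at this position, a number 0.8 percentage points higher from compound 2 to compound 4 (within the scatter), which the earlier compounds could not provide. Although four heavy atoms leave and only one enters, with no hydrogen-bond donor or acceptor on either side, compound 2 and compound 4 stand within the scatter of each other, so this read-out at this single concentration does not separate the two groups in this pair. Nothing at hand accounts for the two groups reading alike here.

The compounds shown leave open how other groups on this same aromatic carbon would read, such as an amine, a carboxylic acid, a methoxy group or a longer alkyl chain. They also leave open whether methyl in place of trifluoromethyl would read the same way on compound 3, and whether a full concentration series would separate compound 2 and compound 4 where a single concentration does not.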